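The source may report more compounds than this note shows. Statements on the series, on what has been measured and on what is new or still open speak of the compounds shown alone.

Measured in a functional assay on K562 cells (Homo sapiens) for antiproliferative activity, read by trypan blue exclusion, with a stated time of 48 h, tested at 10 uM; on this read-out lower numbers stand for less inhibition of growth and higher numbers for more inhibition of growth at the one concentration tested:
Compound 1 `Cc1ccc(NC(=O)/C=C/c2ccccc2)c(C(N)=O)c1`: 65.4%
Compound 2 `Cc1ccccc1/C=C/C(=O)Nc1ccc(Cl)cc1C(N)=O`: 52.2%

Of these two numbers, compound 2 has the lower one, and its gap to compound 1 lies beyond the usual scatter of repeated measurements. Compound 3 `Cc1ccc(/C=C/C(=O)Nc2ccc(Cl)cc2C(N)=O)cc1` has not yet been measured. It contains the same atoms as compound 2, joined differently: 4-methylphenyl in place of 2-methylphenyl on a double-bonded chain carbon bound to a double-bonded chain carbon. Among the compounds with values here, no pair of measured compounds differs in one place only, so the data offer no direct guide to this change. The starting point is therefore compound 2 at 52.2% in this assay, and no change beyond the scatter is expected. The estimated size of the change is a number 2.8 percentage points higher from compound 2 to compound 3 (within the scatter). For compound 3 the expected value is 55%, within an estimated range of 40% to 70%.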

Compound 3, percent growth inhibition at one concentration: 64%
Compound 3: the middle estimate sits 9 percentage points below what was measured; the measured number falls inside the stated range.
By their numbers in this assay, from the lowest: compound 2; then compounds 3 and 1 (each within the scatter of the next).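

In this assay, 4-methylphenyl in place of 2-methylphenyl on a double-bonded chain carbon bound to a double-bonded chain carbon gives a number 11.8 percentage points higher from compound 2 to compound 3 (beyond the scatter). Within the data shown here, this is the first comparison here between compounds that differ in one place only, and it shows that the same atoms, joined differently at this one group, can give a real difference in growth inhibition at the single concentration tested. No measurement at hand says why the two arrangements differ.

From the compounds shown here alone, this is one pair, so it remains open whether the same change would give a similar step on a core with a different set of groups. Going by these compounds, it is also open how other groups in this place, such as 4-methoxyphenyl or 4-chlorophenyl, would compare with 4-methylphenyl.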